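This account rests on a few compounds, and the source may have more. Where it says the series, first, only, none or still open, it means among the compounds named here.

Measured compounds:
Compound 1 `Cc1ccc(CSc2cc(Cl)c(C)cc2S(=O)(=O)/N=C(\N)n2nc(C)cc2-c2ccccc2)cc1` gives 89000 nM in a functional assay on MCF7 cells (Homo sapiens) for cytotoxicity, read by MTT assay, with a stated time of 72 h; on this read-out lower numbers stand for stronger inhibition and higher numbers for weaker inhibition.
Compound 2 `Cc1cc(-c2ccccc2)n(/C(N)=N/S(=O)(=O)c2cc(C)c(Cl)cc2SCc2ccc(C(F)(F)F)cc2)n1` gives 16000 nM in this assay.

For the measured compounds named here, compound 2 holds the lowest of the two numbers measured so far; its nearest neighbour is compound 1, and the step of a 5.6-fold lower number from compound 1 to compound 2 (0.75 log units; beyond the scatter) separates them, a change that lies beyond the usual scatter. Compound 3 `Cc1cc(-c2ccccc2)n(/C(N)=N/S(=O)(=O)c2cc(C)c(Cl)cc2SCc2ccc(Cl)cc2)n1` has not been measured in this assay. It differs from compound 2 in one place: chloro in place of trifluoromethyl on an aromatic carbon.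

Going by the values given here, only one measured step bears on this position, the one from methyl to trifluoromethyl at the same aromatic carbon, which produced a 5.6-fold lower number from compound 1 to compound 2 (0.75 log units; beyond the scatter). Among the compounds with values here, no measured pair shows chloro against trifluoromethyl here, so the direction of the new step rests on the single comparison available. Chloro is smaller than trifluoromethyl but larger than methyl, so the number for compound 3 is expected to land between the two measured values, closer to compound 2, with a modest rise expected as a 1.6-fold higher number from compound 2 to compound 3 (0.19 log units; within the scatter). Compound 3 is therefore estimated at 25000 nM, with a range from 8000 nM to 60000 nM.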

Compound 3, half-maximal inhibitory concentration: 108000 nM
For compound 3 the middle estimate is 4.3-fold (0.64 log units) below the measured one; measured number outside the range, above it.
By their numbers in this assay, from the lowest: compound 2; then compounds 1 and 3 (each within the scatter of the next).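

In this assay the new result shows that the lower number seen with trifluoromethyl at this aromatic carbon does not carry over to chloro: the step of a 6.8-fold higher number from compound 2 to compound 3 (0.83 log units; beyond the scatter) lies beyond the usual scatter and runs opposite to the step of a 5.6-fold lower number from compound 1 to compound 2 (0.75 log units; beyond the scatter) from the earlier pair. Chloro and methyl, by contrast, cannot be told apart at this position, as the step of a 1.2-fold higher number from compound 1 to compound 3 (0.08 log units; within the scatter) stays within the scatter, and so of the three groups shown only trifluoromethyl stands apart from the other two. The data shown offer no explanation for this separation.

The compounds shown leave open whether the separation belongs to trifluoromethyl alone or is shared by other groups at this carbon, such as a methoxy, a nitrile, a fluoro or an amine. They also leave open whether the same order of groups would hold with a longer chain in place of the benzyl link to the sulfur, or on cell lines other than this one.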